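Extending the Ketone Side Chain of Compound 3

The source may hold more compounds than are shown below. What is called first, only, known or untested is meant among the compounds shown, and "the series" means these compounds.

Measured in an assay on isolated protein for binding affinity to metabotropic glutamate receptor 2 (Homo sapiens), read by GTPgammaS binding; on this read-out lower numbers stand for an effect already at smaller amounts and higher numbers for an effect only at larger amounts of compound:
Compound 1 `CCCc1c(OCCCCOc2ccc(-c3nn[nH]n3)cc2)ccc(C(C)=O)c1O`: 348 nM
Compound 2 `CCCc1c(OCCCCNc2ccc(-c3nn[nH]n3)cc2)ccc(C(C)=O)c1O`: 939 nM
Compound 3 `CC(=O)c1ccc(OCCCCOc2ccc(-c3nn[nH]n3)cc2)c(Br)c1O`: 878 nM

Compound 3 holds the second highest of the three numbers in this assay. Its value lies within the scatter of that of compound 2, so no order between those two can be claimed. Among the measured compounds shown here, the one measured step, a 2.5-fold higher number from compound 1 to compound 3 (0.40 log units; beyond the scatter), separates compound 3 from compound 1 by a modest amount beyond the scatter.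

Compound 4 `CC(C)CC(=O)c1ccc(OCCCCOc2ccc(-c3nn[nH]n3)cc2)c(Br)c1O` differs from compound 3 by isopropyl in place of hydrogen on a saturated chain carbon bound to a carbonyl carbon, so the acetyl group of the shared core becomes an isobutylcarbonyl group. For the measured compounds named here, no measured step concerns this part of the molecule: the step from compound 1 to compound 3 changes a ring substituent, and compound 2 differs from compound 1 in the linking chain. With nothing to go on, a shift no larger than the scatter is expected, in no particular direction, with wide uncertainty. Compound 4 is therefore estimated at 900 nM, with a range from 300 nM to 2700 nM. The expected step is a 1.0-fold higher number from compound 3 to compound 4 (0.01 log units; within the scatter).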

Compound 4, half-maximal effective concentration: 93 nM
Compound 4: the middle estimate sits 9.7-fold (0.99 log units) above what was measured; the measured number lies below the stated range.
By their numbers in this assay, from the lowest: compound 4; then compound 1; then compounds 3 and 2 (each within the scatter of the next).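

In this assay, among the compounds shown here, the side chain of the ketone proves to be a part of the molecule where a change can move the number, something the earlier compounds could not show because none of them varied it. Going from acetyl to isobutylcarbonyl gives a 9.4-fold lower number from compound 3 to compound 4 (0.98 log units; beyond the scatter) and shifts the result towards effect at smaller amounts, so at this position the added isopropyl, made up of carbon alone, is tolerated and goes with a clear improvement. Nothing measured here explains why this happens.

The compounds shown leave open whether the branching matters, or whether an unbranched pentanoyl chain, a cyclohexyl group or a terminal amine at this position would do as well. They also leave open whether the same extension would lower the number when propyl replaces bromo on the shared core.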